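The compounds below may be only part of what the source reports. "The series", "measured", "known", "first", "only" and "open" are said of these compounds alone.

Measured so far:
compound 1, `COc1ccc(CNc2nc([Se]C)nc3ccccc23)cc1`, gives 75600 nM in an ADME assay on 184B5 cells (Homo sapiens) for cytotoxicity, read by MTT assay, with a stated time of 72 h; on this read-out lower numbers stand for stronger inhibition of growth and higher numbers for weaker inhibition of growth
compound 2, `C[Se]c1nc(NCc2ccccc2)c2ccccc2n1`, gives 3720 nM
compound 3, `CSc1nc(NCc2ccccc2)c2ccccc2n1`, gives 28900 nM

Compound 2 and compound 3 differ at one place on the core: a group of 2 heavy atoms (1 carbon, 1 sulfur; no ring) in place of a group of 2 heavy atoms (1 carbon, 1 selenium; no ring), on an aromatic carbon. That change gave a 7.8-fold higher number from compound 2 to compound 3 (0.89 log units; beyond the scatter). Compound 1 differs from compound 2 at one place: methoxy in place of hydrogen on an aromatic carbon. That change gave a 20-fold higher number from compound 2 to compound 1 (1.31 log units; beyond the scatter).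

Compound 4, `COc1ccc(CNc2nc(SC)nc3ccccc23)cc1`, has not yet been measured in this assay. It differs from compound 3 at one place: methoxy in place of hydrogen on an aromatic carbon. The place is described in the same words as for the change from compound 2 to compound 1, so this is the same change, seen only once before, and there on the core of compound 2 rather than that of compound 3. Compound 4 is expected to show an 8.7-fold higher number from compound 3 to compound 4 (0.94 log units; beyond the scatter) because the same change gave a 20-fold higher number from compound 2 to compound 1 (1.31 log units; beyond the scatter). Compound 4 is therefore estimated at 250000 nM in this assay, expected to fall between 80000 nM and 800000 nM, with a real chance that only a limit is reported.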

Compound 4, concentration for 50% growth inhibition: 85600 nM
Compound 4: middle estimate off by 2.9-fold (0.47 log units), on the high side, within the range that was stated.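

In this assay, methoxy in place of hydrogen on an aromatic carbon, para to a large group, gave a higher number on both cores, but a 3.0-fold higher number from compound 3 to compound 4 (0.47 log units; beyond the scatter) is a much smaller step than the one seen on the core of compound 2: the same change on two cores in this assay, a 20-fold higher number (1.31 log units; beyond the scatter) from compound 2 to compound 1 and a 3.0-fold higher number (0.47 log units; beyond the scatter) from compound 3 to compound 4, 6.9-fold (0.84 log units) apart, beyond the scatter of two such steps

Putting the carbon and sulfur group in place of the carbon and selenium group gave a 1.1-fold higher number from compound 1 to compound 4 (0.05 log units; within the scatter), whereas the same exchange without methoxy gave a step beyond the scatter: the same change on two cores in this assay, a 7.8-fold higher number (0.89 log units; beyond the scatter) from compound 2 to compound 3 and a 1.1-fold higher number (0.05 log units; within the scatter) from compound 1 to compound 4, 6.9-fold (0.84 log units) apart, beyond the scatter of two such steps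

The size of neither change therefore carries from one core to another in this series, yet both gaps come from the same four compounds, so they are a single observation that the two changes do not simply add up, and they show neither how general this is nor why it happens.

The compounds shown leave open whether a chlorine atom or a hydroxyl group in the place of methoxy would follow the same pattern. They also leave open how an ethyl chain in place of the methyl on selenium or sulfur would behave.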